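The compounds below may be only part of what the source reports. "The series", "measured", "known", "first", "only" and "open" are said of these compounds alone.

In a functional assay on DU-145 cells (Homo sapiens) for cytotoxicity, read by MTT assay, with a stated time of 48 h (a higher number here means a weaker inhibitor, a lower number a stronger inhibitor), compound 1 `COc1ccc(/C=C/c2cc(OC)c(OC)c(OC)c2-c2ccc3ccccc3c2)cc1` gives 32000 nM. Compound 2 `C=C(c1ccc(OC)cc1)c1cc(OC)c(OC)c(OC)c1-c1ccccc1` gives 8000 nM, which is the lower of the two numbers, and the gap between them lies beyond the usual scatter of repeated measurements. Compound 2 is therefore the stronger inhibitor of this measured pair, although both numbers are large on this scale.

Compound 3 `C=C(c1ccc(OC)cc1)c1cc(OC)c(OC)c(OC)c1-c1ccc(Cl)cc1` is built from compound 2 by a single change: chloro in place of hydrogen on an aromatic carbon. In words, a chloro group takes the place of hydrogen on an aromatic carbon of a six-membered aromatic ring of carbon only, para to a large group, so that phenyl becomes 4-chlorophenyl.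

The two measured compounds differ in more than one place, so the data hold no direct guide to this swap. Among the measured compounds shown here, with no measured precedent to point either way, no shift beyond the scatter is expected in this assay, and the expected step is a 1.1-fold lower number from compound 2 to compound 3 (0.06 log units; within the scatter).

For compound 3 the estimated value is 7000 nM, with an expected range from 2500 nM to 20000 nM.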

Compound 3, half-maximal inhibitory concentration: 33000 nM
Compound 3: middle estimate off by 4.7-fold (0.67 log units), on the low side; measured number outside the range, above it.
By their numbers in this assay, from the lowest: compound 2; then compounds 1 and 3 (each within the scatter of the next).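

In this assay, among the compounds shown here, compounds 2 and 3 form the first pair that differs in only one place, and putting chloro in place of hydrogen gives a 4.1-fold higher number from compound 2 to compound 3 (0.62 log units; beyond the scatter). This shows that the aromatic carbon para to a large group is not a neutral place for this change: turning phenyl into 4-chlorophenyl adds a single chlorine atom, yet it moves the number beyond the scatter and towards weaker inhibition, at least on this one core. The compounds shown offer no independent measurement that explains this step.

On these data alone, it remains open whether this loss is specific to chloro or would also appear with another group at the same carbon, such as fluoro, methyl, methoxy or an amine. Also unresolved is whether the same swap would shift the number similarly on the core of compound 1, which carries a different arrangement around its double bond and a larger aromatic group in this position.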